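A chlorine-bearing ring gives way to an open chain

The source may hold more compounds than are shown below. What is called first, only, known or untested is meant among the compounds shown, and "the series" means these compounds.

Compound 2 `CN(C)C(=S)SC(=S)N1CCN(c2cccc(Cl)c2)CC1` is the only one of the three measured compounds without a number: in an ADME assay on HeLa cells (Homo sapiens) for cytotoxicity, read by MTT assay, with a stated time of 24 h (a lower number here means a stronger inhibitor, a higher number a weaker inhibitor), compound 2 gives only a limit, > 5000000 nM, (the limit of > 5000000 nM in this assay, at which 1 of the 3 values shown sits). Compound 1 `CN(C)C(=S)SC(=S)N1CCN(c2cccc(C(F)(F)F)c2)CC1` gives 2760000 nM in this assay, and compound 3 `CN(C)C(=S)SC(=S)N1CCN(c2cccc(Cl)c2Cl)CC1` gives 1590000 nM in this assay. The two steps leading to and from compound 2 are an at least 1.8-fold higher number from compound 1 to compound 2 (0.25 log units; that floor lies within the scatter) and an at least 3.1-fold lower number from compound 2 to compound 3 (0.49 log units; beyond the scatter).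

Compound 4 `CCCCNC(=S)N1CCN(C(=S)SC(=S)N(C)C)CC1` is not yet measured. It differs from compound 2 by a group of 7 heavy atoms (5 carbon, 1 nitrogen, 1 sulfur; no ring) in place of a group of 7 heavy atoms (6 carbon, 1 chlorine; one six-membered aromatic ring of carbon only), on an amine nitrogen in a ring. For the measured compounds named here, both measured steps alter a substituent on the aromatic ring while keeping that ring; neither removes the ring, so neither speaks directly to this change, and they show only that small changes around the ring move the number modestly at most.

Compound 4 is therefore expected to remain a weak inhibitor in this assay, with an estimated value of 3000000 nM, between 800000 nM and 10000000 nM. The step of an at least 1.6-fold lower number from compound 2 to compound 4 (0.22 log units; that floor lies within the scatter) is the expected size, with a fair chance that only a limit is reported again.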

Compound 4, half-maximal inhibitory concentration: 2840000 nM
Beside the measured number, compound 4's estimate is 1.1-fold (0.02 log units) above it; the measured number falls inside the stated range.
By their numbers in this assay, from the lowest: compounds 3, 1 and 4 (each within the scatter of the next). At a limit, above all of these: compound 2.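

In this assay, the 3-chlorophenyl group on the ring nitrogen gives way to an open group with no ring, and compound 4 gives a measured number, 2840000 nM. The earlier steps shown here changed only substituents on the aromatic ring, whereas this one shows that a number within the assay's range can be reached with that ring gone altogether. The change reads as an at least 1.7-fold lower number from compound 2 to compound 4 (0.24 log units; that floor lies within the scatter), so it shows no clear gain, and its size rests on a limit rather than a number: the limit of > 5000000 nM in this assay, at which 1 of the 4 values shown sits.

From the compounds shown here alone, it remains open whether the sulfur of the entering group matters, which a carbonyl in its place would test. Going by these compounds, it is also open whether a longer chain or a carboxylic acid on this nitrogen would shift the number beyond the scatter.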